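This account rests on a few compounds, and the source may have more. Where it says the series, first, only, none or still open, it means among the compounds named here.

The measured compounds:
Compound 1 `CN(C)S(=O)(=O)Nc1cccc2c1CCCC2c1c[nH]cn1` gives < 10000 nM in an assay on isolated protein (Cricetulus griseus) for binding affinity to Alpha-1B adrenergic receptor (Mesocricetus auratus), read by radioligand binding; a lower number here means a stronger inhibitor, a higher number a weaker inhibitor; this value is a limit of the assay.
Compound 2 `CCS(=O)(=O)Nc1cc(F)cc2c1CCCC2c1c[nH]cn1` gives < 10000 nM in this assay; this too is a limit.
Compound 3 `COc1ccc(NS(C)(=O)=O)c2c1C(c1c[nH]cn1)CCC2` gives < 10000 nM in this assay; again only a limit.

Compound 3 thus stands at a limit, and so does every other value shown: the limit of < 10000 nM in this assay, at which 3 of the 3 values shown sit. Compound 4 `CS(=O)(=O)Nc1ccc(F)c2c1CCCC2c1c[nH]cn1` differs from compound 3 in one place: fluoro in place of methoxy on an aromatic carbon. Among the measured compounds shown here, no measured pair carries this change, and every value shown is a limit, so the size of the step in this assay cannot be read from the numbers; the account expects no step beyond the usual scatter, in either direction. Compound 4 is estimated at 1000 nM, with a range of 100 nM to 10000 nM. The step from compound 3 to compound 4 is expected to be a step that the limit leaves unreadable from compound 3 to compound 4.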

Compound 4, inhibition constant: < 10000 nM
Compound 4: no number, only a limit (the forecaster's own chance of this, stated with the estimate: 60%); the middle value is on the limit's open side.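

No step can be read between compound 3 and compound 4, because both values are limits: the limit of < 10000 nM in this assay, at which 4 of the 4 values shown sit. The compounds shown leave open how strongly each one binds, and whether fluoro in place of methoxy shifts the value at all.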